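The compounds below may be only part of what the source reports. "The series", "measured", "known", "first", "only" and "open" are said of these compounds alone.

Measured in a functional assay on MDA-MB-231 cells (Homo sapiens) for antiproliferative activity, read by MTT assay, with a stated time of 24 h; on this read-out higher numbers stand for weaker inhibition and lower numbers for stronger inhibition:
Compound 1 `Cc1ccccc1NNC(=O)c1ccccc1NS(=O)(=O)c1cnc(O)nc1O`: > 20000 nM (a limit)
Compound 2 `O=C(NNc1ccccc1F)c1ccccc1NS(=O)(=O)c1cnc(O)nc1O`: > 20000 nM (a limit)
Compound 3 `CCCCOc1ccc(C(=O)NNC(=O)c2ccccc2NS(=O)(=O)c2cnc(O)nc2O)cc1`: 6830 nM

Among the compounds with values here, compound 3 is the only compound with a number. The other two stand at the limit of > 20000 nM in this assay, at which 2 of the 3 values shown sit. Compound 4 `Cc1ccccc1C(=O)NNC(=O)c1ccccc1NS(=O)(=O)c1cnc(O)nc1O` differs from compound 3 by 2-methylphenyl in place of 4-butoxyphenyl on a carbonyl carbon. Within the data shown here, the one measured step, a step that the two limits leave unreadable from compound 1 to compound 2, concerns a different change and gives no size to carry over. Compound 1 also carries 2-methylphenyl and gives > 20000 nM, a limit of the assay. On that basis, a move towards weaker inhibition is expected in this assay, with an expected 2.2-fold higher number from compound 3 to compound 4 (0.34 log units; beyond the scatter), though its size is uncertain. Compound 4 is estimated at 15000 nM, with an expected range of 6000 nM to 40000 nM.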

Compound 4, half-maximal inhibitory concentration: 5570 nM
Estimate against measurement, compound 4: 2.7-fold (0.43 log units) above, and the stated range ends above it.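

In this assay the step of a 1.2-fold lower number from compound 3 to compound 4 (0.09 log units; within the scatter) shows, for 2-methylphenyl in place of 4-butoxyphenyl on a carbonyl carbon, that a measured number does not depend on 4-butoxyphenyl. Putting (2-methylphenyl)carbonyl in place of 2-methylphenyl on an amine nitrogen gives an at least 3.5-fold lower number from compound 1 to compound 4 (0.55 log units; beyond the scatter) and putting it in place of 2-fluorophenyl gives an at least 3.5-fold lower number from compound 2 to compound 4 (0.55 log units; beyond the scatter) so among these compounds only those with this carbonyl reach a number. As far as these compounds go, both steps start from a limit, and their full size stays unknown: the limit of > 20000 nM in this assay, at which 2 of the 4 values shown sit. From the compounds shown here alone, whether a carboxylic acid or an amine on this carbonyl carbon would keep a number in this assay remains open.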